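One Inverted Stereocentre on a Weakly Active Amide

This account rests on a few compounds, and the source may have more. Where it says the series, first, only, none or still open, it means among the compounds named here.

For the measured compounds named here, compound 1 `CCCC(=O)N[C@@H]1[C@H]2OC(C)(C)O[C@H]2O[C@@H]1[C@H](O)CO` gives 500000 nM in a functional assay on K562 cells (Homo sapiens) for antiproliferative activity (a higher number here means a weaker inhibitor, a lower number a stronger inhibitor), and holds the lower, stronger of the two numbers known so far. Compound 2 `CCCCCC(=O)N[C@@H]1[C@H]2OC(C)(C)O[C@H]2O[C@@H]1[C@H](O)CO` reads 10000000 nM on the same measure. Going by the values given here, the only measured step is a 20-fold higher number from compound 1 to compound 2 (1.30 log units; beyond the scatter) and it comes from extending the chain on the carbonyl, with configuration untouched. Compound 3 `CCCC(=O)N[C@H]1[C@H]2OC(C)(C)O[C@H]2O[C@@H]1[C@H](O)CO` changes something else: the two compounds have the same atoms and bonds and differ only in configuration as drawn: 1 of 5 stereo elements differ; a stereocentre at a saturated ring carbon is drawn S in compound 1 and R in compound 3 and this stereocentre at a saturated ring carbon is the sole point of contrast with compound 1. Among the compounds with values here, no measured step tests such an inversion. Within the data shown here, the large chain step shows only that one edit to compound 1 can move the number well beyond the scatter. A small rise in this assay is therefore expected, with the direction uncertain. The expected change is a 2.0-fold higher number from compound 1 to compound 3 (0.30 log units; within the scatter) on this estimate. Compound 3 is estimated at 1000000 nM (expected range 150000 nM to 7000000 nM).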

Compound 3, half-maximal inhibitory concentration: 20000000 nM
Beside the measured number, compound 3's estimate is 20-fold (1.30 log units) below it; the measured number lies above the stated range.
By their numbers in this assay, from the lowest: compound 1; then compounds 2 and 3 (each within the scatter of the next).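

Inverting this one saturated ring carbon from S to R, with no atom gained or lost, gives a 40-fold higher number from compound 1 to compound 3 (1.60 log units; beyond the scatter) in this assay. This position is therefore sensitive to configuration alone, a point that the chain step could not show, and within this pair the S form as drawn has the lower, stronger number. The shift can be assigned to this stereocentre because nothing else separates the pair: the fact that compounds 1 and 3 differ only in the configuration as drawn.

Still open, on these data alone, is whether the same inversion would move the number as far with the longer chain of compound 2, or with a free amine in place of the amide. The compounds shown also leave open whether any change to this position could give a much lower number than that of compound 1.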